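The compounds below may be only part of what the source reports. "The series", "measured", "known", "first", "only" and "open" are said of these compounds alone.

Compound 3 `C#CCOCCn1c(N2CCN(C)CC2)nc2ccccc21` is the point of departure. In a functional assay on ileum for inhibition of histamine H1 receptor (Cavia porcellus) (on this read-out lower numbers stand for stronger inhibition and higher numbers for weaker inhibition), compound 3 gives 12 nM. Its two measured companions share the same core and differ only in the side chains: compound 1 `CCSCCn1c(N2CCN(C)CC2)nc2ccccc21` gives 19 nM in this assay, and compound 2 `CCOCCn1c(N2CCN(CC)CC2)nc2ccccc21` gives 18 nM. All three numbers lie within the usual scatter of one another, so compound 3 is not set apart from either neighbour. Among the measured compounds shown here, the one single-site step among them, a 1.6-fold lower number from compound 1 to compound 3 (0.20 log units; within the scatter), exchanged one side chain for another and left the number essentially where it was. Compound 2 differs from compound 3 in two places at once, and its value likewise sits beside that of compound 3.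

The new compound, compound 4 `CCCCOCCn1c(N2CCN(C)CC2)nc2ccccc21`, arises from compound 3 by propyl in place of ethynyl on a saturated chain carbon bound to an oxygen on a saturated carbon. For the measured compounds named here, only the step from compound 1 to compound 3 touches this part of the molecule, and it lay within the scatter; no measured step shows this assay responding to a change at this chain end. Compound 4 is therefore expected to show a 1.3-fold higher number from compound 3 to compound 4 (0.10 log units; within the scatter). The estimated value for compound 4 is 15 nM, with a range from 6 nM to 40 nM.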

Compound 4, half-maximal inhibitory concentration: 38 nM
Compound 4: middle estimate off by 2.5-fold (0.40 log units), on the low side; the range from low to high includes it.
By their numbers in this assay, from the lowest: compounds 3, 2, 1 and 4 (each within the scatter of the next, the first and the last beyond it).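

In this assay, among the compounds shown here, propyl in place of ethynyl on a saturated chain carbon bound to an oxygen on a saturated carbon gives a 3.2-fold higher number from compound 3 to compound 4 (0.50 log units; beyond the scatter), the first step at this chain end to lie beyond the scatter. Butoxy in place of ethylsulfanyl on a saturated chain carbon, two bonds along the chain from an aromatic nitrogen, gives a 2.0-fold higher number from compound 1 to compound 4 (0.30 log units; within the scatter), so that exchange does not separate the two compounds. Nothing at hand accounts for the difference between the propargyloxy and butoxy chains.

Going by these compounds, it remains open whether the step goes with the triple bond that leaves or with the carbon that enters; a propoxy chain and a longer chain ending in ethynyl would tell these apart. Also open, on these data alone, is how a hydroxyl or an amine at this chain end would read out.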